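Methoxy in Place of Fluoro on the Pendant Aryl Ring

This account rests on a few compounds, and the source may have more. Where it says the series, first, only, none or still open, it means among the compounds named here.

Measured compounds in a functional assay on A549 cells (Homo sapiens) for antiproliferative activity, read by MTT assay, with a stated time of 72 h; a lower number here means a stronger inhibitor, a higher number a weaker inhibitor:
compound 1, `CNC(=O)c1cc(Oc2ccc(NC(=O)c3cc4cccnc4n(-c4ccc(F)cc4)c3=O)cc2)ccn1`, 110 nM
compound 2, `CCNC(=O)c1cc(Oc2ccc(NC(=O)c3cc4cccnc4n(-c4ccc(F)cc4)c3=O)cc2)ccn1`, 120 nM

Compound 2 stands highest of the two numbers in this assay, its nearest neighbour being compound 1, with a 1.1-fold higher number from compound 1 to compound 2 (0.04 log units; within the scatter). Compound 3, `CCNC(=O)c1cc(Oc2ccc(NC(=O)c3cc4cccnc4n(-c4ccc(OC)cc4)c3=O)cc2)ccn1`, differs from compound 2 by methoxy in place of fluoro on an aromatic carbon. Among the measured compounds shown here, the only measured step, a 1.1-fold higher number from compound 1 to compound 2 (0.04 log units; within the scatter), concerns the alkyl on the amide nitrogen, not the aryl ring, so no measured step bears on this change. With nothing to lean on, compound 3 is expected to sit close to compound 2, a step of a 1.3-fold higher number from compound 2 to compound 3 (0.10 log units; within the scatter), within the scatter. The estimate for compound 3 in this assay is 150 nM, ranging from 50 nM to 450 nM.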

Compound 3, half-maximal inhibitory concentration: 2010 nM
Compound 3: the middle estimate sits 13-fold (1.13 log units) below what was measured, outside the stated range (above it).
By their numbers in this assay, from the lowest: compounds 1 and 2 (each within the scatter of the next); then compound 3.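

In this assay, the change from 4-fluorophenyl to 4-methoxyphenyl gives a 17-fold higher number from compound 2 to compound 3 (1.22 log units; beyond the scatter). This para position on the pendant ring is therefore sensitive to its substituent, whereas the alkyl change in a 1.1-fold higher number from compound 1 to compound 2 (0.04 log units; within the scatter) stays within the scatter. Nothing measured here explains the loss.

The compounds shown leave open whether the loss follows from removing fluoro or from adding methoxy, and how a chloro, methyl or hydroxy group on the same carbon would compare. They also leave open whether the same change would cost as much on compound 1.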